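The source may hold more compounds than are shown below. What is called first, only, known or untested is meant among the compounds shown, and "the series" means these compounds.

Compound 2 `Cc1nc(N)c2c(-c3cc4ccccc4o3)cn([C@@H]3O[C@H](CO)[C@@H](O)[C@H]3O)c2n1` stands at the edge of what a functional assay on A549 cells (Homo sapiens), read by MTT assay, with a stated time of 72 h (on this read-out lower numbers stand for stronger inhibition and higher numbers for weaker inhibition), can report: in this assay compound 2 gives > 20000 nM, which is a limit of the assay and not a number. Its counterpart compound 1 `Nc1nc(N)c2c(-c3cc4ccccc4o3)cn([C@@H]3O[C@H](CO)[C@@H](O)[C@H]3O)c2n1`, with amino where compound 2 carries methyl, is no different on the numbers shown. In this assay compound 1 gives > 20000 nM, again a limit. The step that the two limits leave unreadable from compound 1 to compound 2 therefore cannot be read, because of the limit of > 20000 nM in this assay, at which 3 of the 3 values shown sit. A third nucleoside with the shared core, compound 3 `Nc1nc2c(c(-c3ccco3)cn2[C@@H]2O[C@H](CO)[C@@H](O)[C@H]2O)c(=O)[nH]1`, also sits at the limit. In this assay compound 3 gives > 20000 nM, once more a limit.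

Compound 4 `C#Cc1cn([C@@H]2O[C@H](CO)[C@@H](O)[C@H]2O)c2nc(C)nc(N)c12` differs from compound 2 in a single place: ethynyl in place of 1-benzofuran-2-yl on an aromatic carbon. For the measured compounds named here, no measured step bears on this change, since the only step recorded concerns methyl in place of amino at another carbon and is itself unreadable. Nothing in the measured values sets a direction or size for the replacement of 1-benzofuran-2-yl by ethynyl, so any expectation must be loose. Compound 4 is estimated to give 500 nM in this assay, with a range from 20 nM to 20000 nM. That estimate would correspond to an expected step of an at least 40-fold lower number from compound 2 to compound 4 (1.60 log units; beyond the scatter).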

Compound 4, half-maximal inhibitory concentration: > 20000 nM
Compound 4 gave a limit, no number; the forecaster's own chance of this, stated with the estimate: 30%; middle value at least 40-fold (1.60 log units) from the limit.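

In this assay compound 4 gives > 20000 nM, a limit and not a number. No step can be read between compound 2 and compound 4 because both stand at this limit: the limit of > 20000 nM in this assay, at which 4 of the 4 values shown sit.

The compounds shown leave open whether ethynyl or 1-benzofuran-2-yl on that aromatic carbon makes any difference to inhibition.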